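Lactam in place of thiazolidinedione on the benzylidene arm

The source may report more compounds than this note shows. Statements on the series, on what has been measured and on what is new or still open speak of the compounds shown alone.

Compound 1 `CCc1cnc(N2CCC(c3nc(COc4ccc(/C=C5\SC(=O)NC5=O)cc4F)cs3)CC2)nc1`: 780 nM
Compound 2 `CCc1cnc(N2CCC(c3nc(COc4ccc(-n5cnnn5)cc4)cs3)CC2)nc1`: 87 nM

In a functional assay on cells for agonist activity at Glucose-dependent insulinotropic receptor (Homo sapiens), read by a luciferase reporter, with a stated time of 6 h (a lower number here means that less compound is needed, a higher number that more compound is needed for the effect), compound 1 gives 780 nM and stands as the higher of the two numbers; compound 2 gives 87 nM, a gap beyond the scatter. Compound 3 `CCc1cnc(N2CCC(c3nc(COc4ccc(/C=C5\CCNC5=O)cc4F)cs3)CC2)nc1` has not been measured. It differs from compound 1 by a group of 7 heavy atoms (5 carbon, 1 nitrogen, 1 oxygen; one five-membered non-aromatic ring with 1 hetero atom) in place of a group of 8 heavy atoms (4 carbon, 1 nitrogen, 2 oxygen, 1 sulfur; one five-membered non-aromatic ring with 2 hetero atoms), on an aromatic carbon. Among the measured compounds shown here, no measured pair shows this exchange, so the expectation rests on compound 1 alone. The step of a 3.2-fold higher number from compound 1 to compound 3 (0.51 log units; beyond the scatter) is expected to run toward a higher number. Compound 3 is estimated at 2500 nM, within 600 nM to 10000 nM.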

Compound 3, half-maximal effective concentration: 100 nM
Compound 3: middle estimate off by 25-fold (1.40 log units), on the high side, and the stated range ends above it.
By their numbers in this assay, from the lowest: compounds 2 and 3 (each within the scatter of the next); then compound 1.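

The lactam in place of the thiazolidinedione gives a 7.8-fold lower number from compound 1 to compound 3 (0.89 log units; beyond the scatter) in this assay, at the position meta to a fluoro group. The thiazolidinedione, with its sulfur and second carbonyl, is therefore not needed for activity on this arm, and less compound is needed without them. Nothing measured here explains the change.

Going by these compounds, whether a six-membered lactam, an open-chain amide or a carboxylic acid would serve on the same arm remains open. So does the effect of removing the fluoro group from the lactam compound.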